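Hydroxyphenyl position and thienyl attachment in cell cytotoxicity

This account rests on a few compounds, and the source may have more. Where it says the series, first, only, none or still open, it means among the compounds named here.

Compound 1 `Oc1cccc(-c2cc(-c3cccs3)cc(-c3cccc(O)c3)n2)c1` gives 3480 nM in a functional assay on HCT-15 cells (Homo sapiens) for cytotoxicity, read by CCK-8 assay; on this read-out higher numbers stand for weaker inhibition and lower numbers for stronger inhibition. Compound 2 `Oc1ccc(-c2cc(-c3cccs3)cc(-c3cccc(O)c3)n2)cc1` gives 1770 nM in this assay, and compound 3 `Oc1cccc(-c2cc(-c3ccsc3)cc(-c3cccc(O)c3)n2)c1` gives 1630 nM. The change 4-hydroxyphenyl in place of 3-hydroxyphenyl on an aromatic carbon produced a 2.0-fold lower number from compound 1 to compound 2 (0.29 log units; within the scatter). The cores of compound 1 and compound 3 differ by thiophen-3-yl in place of thiophen-2-yl on an aromatic carbon, which gave a 2.1-fold lower number from compound 1 to compound 3 (0.33 log units; beyond the scatter). Compound 4 `Oc1ccc(-c2cc(-c3ccsc3)cc(-c3cccc(O)c3)n2)cc1` has not yet been measured. Within the data shown here, it differs from compound 3 by 4-hydroxyphenyl in place of 3-hydroxyphenyl on an aromatic carbon; this is the same kind of change as the one from compound 1 to compound 2, but the place differs: in compound 3 the changed group is meta to a thiophen-3-yl group, whereas in compound 1 it is meta to a thiophen-2-yl group. Because the earlier step was a 2.0-fold lower number from compound 1 to compound 2 (0.29 log units; within the scatter), a step of similar or slightly smaller size is expected from compound 3 to compound 4, a 1.6-fold lower number from compound 3 to compound 4 (0.21 log units; within the scatter). Compound 4 is therefore estimated at 1000 nM, with a likely range from 450 nM to 2300 nM.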

Compound 4, half-maximal inhibitory concentration: 1180 nM
For compound 4 the middle estimate is 1.2-fold (0.07 log units) below the measured one, and the stated range covers the measured number.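

In this assay, 4-hydroxyphenyl in place of 3-hydroxyphenyl gives a 1.4-fold lower number from compound 3 to compound 4 (0.14 log units; within the scatter) and the size of this step does not differ from that on the other core: the same change on two cores in this assay, a 2.0-fold lower number (0.29 log units; within the scatter) from compound 1 to compound 2 and a 1.4-fold lower number (0.14 log units; within the scatter) from compound 3 to compound 4, 1.4-fold (0.15 log units) apart, within the scatter of two such steps. Thiophen-3-yl in place of thiophen-2-yl gives a 1.5-fold lower number from compound 2 to compound 4 (0.18 log units; within the scatter) and reads the same way: the same change on two cores in this assay, a 2.1-fold lower number (0.33 log units; beyond the scatter) from compound 1 to compound 3 and a 1.5-fold lower number (0.18 log units; within the scatter) from compound 2 to compound 4, 1.4-fold (0.15 log units) apart, within the scatter of two such steps. Each change therefore carries between these two cores without a difference that can be told from the scatter, but both new steps themselves lie within the scatter, so they do not show a real effect of either change on the second core, and two cores say nothing about others.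

Open, as far as these compounds go, is how an amine or a carboxylic acid in place of the hydroxyl would behave on the shared core. Also open, from the compounds shown here alone, is whether a furan in place of the thiophene would follow the same steps.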